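Shortening the side chain to a hydroxyl on a protected sugar core

A few compounds are considered here, and "the series" means these few. Any claim that something is new, unique, unknown or untested is made for them only; others in the source may bear on it.

Compound 1 `CCC[C@@H]1O[C@H](COCc2ccccc2)[C@@H](OCc2ccccc2)[C@H](OCc2ccccc2)[C@H]1O`: 38600 nM
Compound 2 `CCC[C@@H]1O[C@H](CO)[C@@H](O)[C@H](O)[C@H]1O`: > 50000 nM
Compound 3 `CCCC[C@@H]1O[C@H](COCc2ccccc2)[C@@H](OCc2ccccc2)[C@H](OCc2ccccc2)[C@H]1O`: 40100 nM

In a functional assay on HOS cells (Homo sapiens) for antiproliferative activity, read by sulforhodamine B assay (on this read-out lower numbers stand for stronger inhibition of growth and higher numbers for weaker inhibition of growth), compound 3 gives 40100 nM, the higher of the two numbers reported, with compound 1 nearest at 38600 nM. Compound 2, which carries free hydroxyls throughout, gives > 50000 nM in this assay, a limit of the assay rather than a number. Among the measured compounds shown here, the one step measured, a 1.0-fold higher number from compound 1 to compound 3 (0.02 log units; within the scatter), stays within the scatter, so lengthening the chain by one carbon changes nothing that can be read.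

Compound 4 `OCC[C@@H]1O[C@H](COCc2ccccc2)[C@@H](OCc2ccccc2)[C@H](OCc2ccccc2)[C@H]1O` differs from compound 3 by hydroxy in place of ethyl on a saturated chain carbon, two bonds along the chain from a saturated ring carbon. For the measured compounds named here, no measured step covers this change directly. The step from compound 1 to compound 3 suggests that chain length alone does not move this assay, while the free-hydroxyl compound 2 sits at the limit of > 50000 nM in this assay, at which 1 of the 3 values shown sits. Compound 4 is therefore expected to give 48000 nM, between 22000 nM and 110000 nM, and the estimated step of a 1.2-fold higher number from compound 3 to compound 4 (0.08 log units; within the scatter) points toward weaker inhibition of growth, with a real chance that only a limit is reported.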

Compound 4, concentration for 50% growth inhibition: 39700 nM
Compound 4: middle estimate off by 1.2-fold (0.08 log units), on the high side, and the stated range covers the measured number.
By their numbers in this assay, from the lowest: compounds 1, 4 and 3 (each within the scatter of the next). At a limit, above all of these: compound 2.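

In this assay, hydroxy in place of ethyl on this saturated chain carbon, two bonds along the chain from a saturated ring carbon, gives a 1.0-fold lower number from compound 3 to compound 4 (0.00 log units; within the scatter), and hydroxy in place of methyl there gives a 1.0-fold higher number from compound 1 to compound 4 (0.01 log units; within the scatter). The earlier step covered only a change in chain length, whereas these show that a hydrogen-bond donor and acceptor, which the chains of compound 1 and compound 3 do not carry, can enter at this place on the shared core with no readable shift in growth inhibition. Nothing at hand explains why this place accepts the change so readily.

Going by these compounds, whether an amine or a carboxylic acid at this chain carbon would move the number remains open. So does the effect of a much longer chain ending in hydroxy.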